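Pyridine Swap on the Urea Chain: Compound 2 to Compound 3

The compounds below may be only part of what the source reports. "The series", "measured", "known", "first", "only" and "open" are said of these compounds alone.

Measured in a functional assay on A2780 cells (Homo sapiens) for antiproliferative activity, read by sulforhodamine B assay, with a stated time of 72 h; on this read-out higher numbers stand for weaker inhibition and lower numbers for stronger inhibition:
- Compound 1 `Cc1ncccc1CNC(=O)Nc1ccc(S(=O)(=O)c2ccccc2)cc1`: > 2000 nM, a limit of the assay
- Compound 2 `Cc1cncc(CNC(=O)Nc2ccc(S(=O)(=O)c3ccccc3)cc2)c1`: 144 nM

Going by the values given here, compound 2, at 144 nM, holds the only actual number in this assay so far. Compound 3 `O=C(NCc1ccc(Cl)nc1)Nc1ccc(S(=O)(=O)c2ccccc2)cc1` carries 6-chloropyridin-3-yl in place of 5-methylpyridin-3-yl on a saturated chain carbon bound to an amide-type nitrogen. Among the compounds with values here, the one measured step bearing on this, an at least 13-fold lower number from compound 1 to compound 2 (1.14 log units; beyond the scatter), also exchanged one substituted pyridinyl group for another at this place, so a large move is possible here. A weaker result is expected, an estimated 5.6-fold higher number from compound 2 to compound 3 (0.74 log units; beyond the scatter). Compound 3 is expected near 800 nM, with an estimated range of 150 nM to 4000 nM.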

Compound 3, half-maximal inhibitory concentration: > 2000 nM
Compound 3 gave a limit, no number (the forecaster's own chance of this, stated with the estimate: 35%); at least 2.5-fold (0.39 log units) between middle value and limit.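

In this assay, 6-chloropyridin-3-yl in place of 5-methylpyridin-3-yl gives an at least 13-fold higher number from compound 2 to compound 3 (1.14 log units; beyond the scatter), so the large sensitivity at this place is not confined to the swap that links compound 1 and compound 2. Two different substituted pyridinyl groups now fall far short of compound 2, the only one of the three with an actual number: the limit of > 2000 nM in this assay, at which 2 of the 3 values shown sit. The step between compound 1 and compound 3 cannot be read, as both values are limits.

Still open, on these data alone, is how an unsubstituted pyridin-3-yl, a plain phenyl or a 5-chloropyridin-3-yl group would fare on this chain carbon. Without them, the effect of the chlorine cannot be separated from that of its place on the ring.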